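Pyridine N-oxide in place of a dimethylpyridine on an oxytocin scaffold

The compounds below may be only part of what the source reports. "The series", "measured", "known", "first", "only" and "open" are said of these compounds alone.

Measured compounds and their values:
Compound 1, `Cc1ccc([C@H](C(=O)N(C)C)N2C(=O)[C@@H](C3Cc4ccccc4C3)NC(=O)[C@H]2CC(C)C)cn1`: 1.59 nM
Compound 2, `CC[C@H](C)[C@@H]1C(=O)N[C@H](C2Cc3ccccc3C2)C(=O)N1[C@@H](C(=O)N(C)C)c1ccc(C)nc1C`: 0.0794 nM
Compound 3, `CC[C@H](C)[C@@H]1C(=O)N[C@H](C2Cc3ccccc3C2)C(=O)N1[C@@H](C(=O)N1CCOCC1)c1cc(C)cnc1C`: 0.794 nM

In an assay on isolated protein for displacement of a labelled ligand from Oxytocin receptor (Homo sapiens) (a higher number here means a weaker inhibitor, a lower number a stronger inhibitor), compound 2 gives the lowest number of the three and is the strongest binder here, its nearest neighbour being compound 3 and the furthest compound 1, both beyond the scatter. Compound 4, `CC[C@H](C)[C@@H]1C(=O)N[C@H](C2Cc3ccccc3C2)C(=O)N1[C@@H](C(=O)N(C)C)c1ccc(C)[n+]([O-])c1`, is not yet measured. It differs from compound 2 by a group of 8 heavy atoms (6 carbon, 1 nitrogen, 1 oxygen; one six-membered aromatic ring with 1 hetero atom) in place of a group of 8 heavy atoms (7 carbon, 1 nitrogen; one six-membered aromatic ring with 1 hetero atom), on a saturated chain carbon bound to an amide-type nitrogen in a ring and a carbonyl carbon. For the measured compounds named here, no measured pair shows this exact exchange, so the step is judged from the structural change alone: a loss of binding beyond the scatter is expected, of modest size, as the estimated step of a 6.3-fold higher number from compound 2 to compound 4 (0.80 log units; beyond the scatter) indicates. Compound 4 is therefore expected to give about 0.5 nM, within a range from 0.1 nM to 3 nM.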

Compound 4, inhibition constant: 1 nM
Compound 4: the middle estimate sits 2.0-fold (0.30 log units) below what was measured; the range from low to high includes it.
By their numbers in this assay, from the lowest: compound 2; then compounds 3, 4 and 1 (each within the scatter of the next).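

In this assay, exchanging the 2,6-dimethylpyridin-3-yl group for the pyridine N-oxide on this saturated chain carbon gives a 13-fold higher number from compound 2 to compound 4 (1.10 log units; beyond the scatter), a large loss of binding. For the compounds shown here, this is the first step at this position that can be read from a single change, and it shows that binding here responds strongly to the aryl group. No measurement shown explains the loss. The exchange alters the methyl substitution and adds the oxide oxygen together, and the compounds shown do not separate the two. Going by these compounds, how a phenyl ring would fare at this carbon also remains open.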